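The source may report more compounds than this note shows. Statements on the series, on what has been measured and on what is new or still open speak of the compounds shown alone.

Measured in a functional assay on the whole organism for agonist activity, with Mus musculus as the target; on this read-out higher numbers stand for an effect only at larger amounts of compound and lower numbers for an effect already at smaller amounts:
- compound 1 `CC(=O)N(C)C(C)C#CCn1cncc1C`: > 100 mg/kg (a limit)
- compound 2 `CCOC(=O)N(C)CC#CCn1ccnc1`: > 100 mg/kg (a limit)
- compound 3 `CCOC(=O)N(C)CC#CCn1cncc1C`: > 100 mg/kg (a limit)

All values in the series sit at the same limit (the limit of > 100 mg/kg in this assay, at which 3 of the 3 values shown sit). Compound 3 therefore offers only a limit as a starting point, with no number.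

Compound 4 `CCOC(=O)N(C)C(C)C#CCn1cncc1C` carries methyl in place of hydrogen on a saturated chain carbon bound to an amide-type nitrogen and a triple-bonded carbon. Among the compounds with values here, the only measured step, a step that the two limits leave unreadable from compound 2 to compound 3, places a methyl on an aromatic carbon instead, and it provides no size to carry over. Compound 1 also carries the chain methyl and gives > 100 mg/kg, which is a limit. No direction can be expected from these data, and compound 4 is expected to stay at the limit in this assay. The estimated change is a step that the limit leaves unreadable from compound 3 to compound 4. For compound 4 the estimate is 120 mg/kg. The expected range for compound 4 runs from 50 mg/kg to 300 mg/kg.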

Compound 4, dose for half-maximal effect: > 100 mg/kg
Compound 4 ended at the assay's limit; the forecaster's own chance of this, stated with the estimate: 80%; the middle value lies beyond the limit too.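

Compound 4 gives no readable step against compound 3 or compound 1, because all of these values are limits: the limit of > 100 mg/kg in this assay, at which 4 of the 4 values shown sit.

The compounds shown leave open whether methyl on the saturated chain carbon, methyl on the aromatic carbon or ethoxy in place of methyl changes the response in this assay at all.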